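The compounds below may be only part of what the source reports. "The series", "measured", "known", "first", "only" and "open" are said of these compounds alone.

Compound 3 `CCCC(CC)(CC)C(=O)O[C@H]1C[C@@H](C)C=C2C=C[C@H](C)[C@H](CC[C@@H]3C[C@@H](O)CC(=O)O3)C21` gives 1.9 nM in an assay for inhibition of 3-hydroxy-3-methylglutaryl-coenzyme A reductase (Rattus norvegicus) (on this read-out higher numbers stand for weaker inhibition and lower numbers for stronger inhibition), the lowest of the three numbers measured. Compound 2 `CC(CC(=O)O[C@H]1C[C@@H](C)C=C2C=C[C@H](C)[C@H](CC[C@@H]3C[C@@H](O)CC(=O)O3)C21)C(F)(F)F` gives 3.5 nM, and the step of a 1.8-fold lower number from compound 2 to compound 3 (0.27 log units; within the scatter) stays within the scatter, so the two cannot be ranked. Compound 1 `CC(C)C(=O)O[C@H]1C[C@@H](C)C=C2C=C[C@H](C)[C@H](CC[C@@H]3C[C@@H](O)CC(=O)O3)C21` gives 7.7 nM, and the step of a 4.1-fold lower number from compound 1 to compound 3 (0.61 log units; beyond the scatter) lies beyond the scatter, as does the step of a 2.2-fold lower number from compound 1 to compound 2 (0.34 log units; beyond the scatter). Compound 4 `C[C@H]1C=C2C=C[C@H](C)[C@H](CC[C@@H]3C[C@@H](O)CC(=O)O3)C2[C@@H](OC(=O)Oc2ccccc2)C1` carries phenoxy in place of 1,1-diethylbutyl on a carbonyl carbon, so that a (1,1-diethylbutyl)carbonyl becomes a phenoxycarbonyl. All three measured steps vary the group on the carbonyl carbon: the two steps away from isopropyl are modest lowerings, while 2-(trifluoromethyl)propyl and 1,1-diethylbutyl are indistinguishable in this assay. None of them brings an aromatic ring or an oxygen onto the carbonyl carbon, so they give no direct guide to phenoxy. The spread among the measured groups is modest, and so the expected step of a 2.1-fold higher number from compound 3 to compound 4 (0.32 log units; beyond the scatter) is small, most likely toward a somewhat higher number but not clearly beyond the scatter. Compound 4 is therefore estimated at 4 nM, with a range from 1.5 nM to 12 nM.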

Compound 4, half-maximal inhibitory concentration: 83 nM
Estimate against measurement, compound 4: 21-fold (1.32 log units) below; measured number outside the range, above it.
By their numbers in this assay, from the lowest: compounds 3 and 2 (each within the scatter of the next); then compound 1; then compound 4.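

Among the groups on this carbonyl carbon, phenoxy is the first to produce a large change in this assay: the steps are a 44-fold higher number from compound 3 to compound 4 (1.64 log units; beyond the scatter), a 24-fold higher number from compound 2 to compound 4 (1.38 log units; beyond the scatter) and an 11-fold higher number from compound 1 to compound 4 (1.03 log units; beyond the scatter), which leaves compound 4 the weakest of the four on this read-out. The position therefore tolerates isopropyl, 2-(trifluoromethyl)propyl and 1,1-diethylbutyl with only modest differences, but it is not indifferent to every group, since the steps away from all three are large and point the same way. The data shown offer no measurement that explains this rise.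

Phenoxy brings an oxygen onto the carbonyl carbon and a six-membered aromatic ring in one change, and the compounds shown cannot say which of the two accompanies the higher number. A benzyl group, which keeps the ring on a carbon, and an ethoxy group, which keeps the oxygen without the ring, would pull these two apart, while an amine on the carbonyl carbon remains an open case as well.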